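Swapping a cyclohexyl for an ethyl on the isoxazole

The source may report more compounds than this note shows. Statements on the series, on what has been measured and on what is new or still open speak of the compounds shown alone.

Measured compounds:
Compound 1, `CC(C)n1nc(-c2cc(C3CCCCC3)on2)c2c(N)ncnc21`, gives 9500 nM.
Compound 2, `Nc1ncnc2c1c(-c1cc(C3CC3)on1)nn2C1CCCCC1`, gives 520 nM.
Compound 3, `Cn1nc(-c2cc(C3CC3)on2)c2c(N)ncnc21`, gives 2670 nM.

These three compounds share one core and were tested in an assay on BaF3 cells for inhibition of proto-oncogene tyrosine-protein kinase receptor Ret (Homo sapiens), read by MTT assay, with a stated time of 48 h; a higher number here means a weaker inhibitor of growth, a lower number a stronger inhibitor of growth. On these numbers compound 1 stands highest of the three: compound 3 sits nearest to it, and compound 2 sits furthest away with the lowest number of the set.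

For the measured compounds named here, the only change so far that alters a single place is the one from compound 2 to compound 3, where a methyl replaces a cyclohexyl on an aromatic nitrogen, and it gave a 5.1-fold higher number from compound 2 to compound 3 (0.71 log units; beyond the scatter). That step concerns the group on the nitrogen, not the group on the isoxazole ring.

Compound 4, `CCc1cc(-c2nn(C(C)C)c3ncnc(N)c23)no1`, is not yet measured. It differs from compound 1 by ethyl in place of cyclohexyl on an aromatic carbon. Going by the values given here, no measured step touches this position, so nothing can be read across directly. Compounds 2 and 3 both carry a smaller cyclopropyl at that carbon and both show lower numbers than compound 1, but each also differs from compound 1 on the nitrogen, so the two changes cannot be separated.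

Compound 4 is therefore expected to give a lower number than compound 1, estimated at 4000 nM with a range from 1000 nM to 15000 nM. This corresponds to an expected step of a 2.4-fold lower number from compound 1 to compound 4 (0.38 log units; beyond the scatter).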

Compound 4, concentration for 50% growth inhibition: 1560 nM
Compound 4: middle estimate off by 2.6-fold (0.41 log units), on the high side; the range from low to high includes it.
By their numbers in this assay, from the lowest: compound 2; then compounds 4 and 3 (each within the scatter of the next); then compound 1.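

In this assay, the step that changes only the group on this aromatic carbon, next to the ring oxygen, gives a 6.1-fold lower number from compound 1 to compound 4 (0.78 log units; beyond the scatter) and leaves the rest of the molecule untouched. For the compounds shown here, this shows that the group at this position affects the number on its own, something the earlier compounds could not show, as each of them also differed from compound 1 on the nitrogen. In this pair, replacing the cyclohexyl, with its six-membered non-aromatic carbon ring and 6 heavy atoms, with an ethyl of 2 heavy atoms gives the lower number, but no measurement shown here explains that difference.

Going by these compounds, a single pair does not show how the number responds across a series of groups at this carbon, so it remains open what a methyl, a longer chain such as butyl, an amine or a carboxylic acid would give there. On these data alone, it is also open whether the step from cyclohexyl to ethyl would be similar with a methyl or a cyclohexyl on the nitrogen of the shared core.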